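The source may report more compounds than this note shows. Statements on the series, on what has been measured and on what is new or still open speak of the compounds shown alone.

The series shares the core of compound 1 `O=C(Cc1ccccn1)c1cc2ccccc2[nH]1`, which in an in vitro assay on P815B cells for inhibition of Indoleamine 2,3-dioxygenase 1 (Mus musculus), tested at 20 uM (a lower number here means less inhibition, a higher number more inhibition at the concentration tested (going by the name of the read-out)), gives 10%. Compound 2 `O=C(Cc1cccnc1)c1cc2cc([N+](=O)[O-])ccc2[nH]1` carries a nitro group on that core, and compound 3 `O=C(Cc1cccnc1)c1cc2c(Cl)cc(Cl)cc2[nH]1` carries two chlorine substituents. In this assay compound 2 is reported as "not active" (no number reported), so no single number stands for it, and compound 3 likewise returns "not active" (no number reported); compound 2 thus stands without a figure of its own, alongside one further entry of the same kind.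

Compound 4 `O=C(Cc1cccnc1)c1cc2cc(OC(F)(F)F)ccc2[nH]1` has not yet been measured in this assay. It differs from compound 2 in one place: trifluoromethoxy in place of nitro on an aromatic carbon, on an aromatic carbon of a six-membered aromatic ring of carbon only, part of a fused or bridged system of two rings, meta to a fused ring and para to a fused ring. With no numbered value for compound 2, the step from compound 2 to compound 4 in this assay is expected to stay within the scatter, in no clear direction. On this basis compound 4 is expected to show about 5% in this assay, estimated between 0% and 20%, with a fair chance that it too is reported only as not active.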

Compound 4, a percentage reported as inhibition, at one concentration (the size of the read-out at that concentration, not a potency): 12%
Estimate against measurement, compound 4: 7 percentage points below, and the stated range covers the measured number.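

Compound 2 has no number in this assay, so the step from it to compound 4 cannot be read. The compounds shown leave open how trifluoromethoxy and nitro compare on the shared core in this assay. No measurement at hand bears on this result.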